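Triazole series: aryl swap on the five-membered ring

The compounds below may be only part of what the source reports. "The series", "measured", "known", "first", "only" and "open" are said of these compounds alone.

Measured so far in a functional assay on CCRF-CEM cells (Homo sapiens) for inhibition, read by MTT assay, with a stated time of 2 days, tested at 10 uM; on this read-out lower numbers stand for less inhibition and higher numbers for more inhibition at the one concentration tested (going by the name of the read-out):
compound 1 `O=C(OCCCc1ccccc1)c1cc(-n2cc(-c3cccc(O)c3)nn2)ccc1O` gives 9%
compound 2 `COc1ccccc1-c1cn(-c2ccc(O)c(C(=O)Nc3cccc(C(F)(F)F)c3)c2)nn1` gives 65%
compound 3 `O=C(O)c1cc(-n2cc(-c3cccc(O)c3)nn2)ccc1O` gives 3%

Compound 1 stands second of the three numbers. For the measured compounds named here, its nearest neighbour is compound 3, and the one step measured, a number 6 percentage points lower from compound 1 to compound 3 (within the scatter), shows that hydrogen in place of 3-phenylpropyl on the oxygen next to the carbonyl group leaves the read-out where it was. Compound 2 lies far higher, but compound 2 differs from compound 1 in more than one place, so its value only says that a much stronger inhibition is reachable within this core; it does not isolate any single change.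

Compound 4 `COc1ccc(-c2cn(-c3ccc(O)c(C(=O)OCCCc4ccccc4)c3)nn2)cc1` is not yet measured. It differs from compound 1 as follows: 4-methoxyphenyl in place of 3-hydroxyphenyl on an aromatic carbon. Going by the values given here, no measured pair changes the group on the five-membered ring while keeping everything else fixed, so nothing known bears directly on this change; the only measured step, a number 6 percentage points lower from compound 1 to compound 3 (within the scatter), concerns the ester oxygen and is within the scatter. For compound 4 in this assay the expectation is therefore a step of about a number 5 percentage points higher from compound 1 to compound 4 (within the scatter), likely not beyond the scatter, and the estimate for compound 4 is 14% with a range of 0% to 40%.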

Compound 4, a percentage reported as inhibition, at one concentration (the size of the read-out at that concentration, not a potency): 5%
For compound 4 the middle estimate is 9 percentage points above the measured one; measured number inside the range.
By their numbers in this assay, from the lowest: compounds 3, 4 and 1 (each within the scatter of the next); then compound 2.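

In this assay, for the compounds shown here, 4-methoxyphenyl in place of 3-hydroxyphenyl on the aromatic carbon of the five-membered ring gives a number 4 percentage points lower from compound 1 to compound 4 (within the scatter) and so offers the first direct reading at this position: with the 3-phenylpropyl ester held fixed, the read-out stays where it was. The group that leaves carries 1 hydrogen-bond donor and the group that enters carries 0 hydrogen-bond donors, yet this difference leaves no mark on the read-out in this pair, although both compounds sit at a low level where a loss would be hard to see. No measurement at hand offers a reason for this result.

The compounds shown leave open whether the aryl group at this position matters at all on a more strongly inhibiting background, since the only pair that changes it carries the ester. They also leave open how a different group at this position would read, such as a 4-aminophenyl group or an unsubstituted phenyl group, on the ester or on the amide core of compound 2.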